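Working notes on the shared-core amides: phenyl for methyl

This account rests on a few compounds, and the source may have more. Where it says the series, first, only, none or still open, it means among the compounds named here.

Measured so far in a functional assay (Homo sapiens), tested at 10 uM; a higher number here means a weaker effect of the compound at the concentration tested, a lower number a stronger effect:
Compound 1, `O=C(CCCc1ccc([N+](=O)[O-])cn1)N1CCc2c(Cl)c(O)c(O)c(Cl)c2C1`: 33%
Compound 2, `O=C(CCCc1ncc(C(F)(F)F)cc1Cl)N1CCc2c(Cl)c(O)c(O)c(Cl)c2C1`: 5%
Compound 3, `Cc1cc(C(F)(F)F)cnc1CCCC(=O)N1CCc2c(Cl)c(O)c(O)c(Cl)c2C1`: 7%

Compound 3 stands second highest of the three numbers. Its nearest neighbour is compound 2, and the step of a number 2 percentage points higher from compound 2 to compound 3 (within the scatter) lies within the scatter. Its furthest neighbour is compound 1, whose number in this assay is higher by an amount beyond the scatter.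

The next compound, compound 4, `O=C(CCCc1ncc(C(F)(F)F)cc1-c1ccccc1)N1CCc2c(Cl)c(O)c(O)c(Cl)c2C1`, has not been measured. It differs from compound 3 in one place: phenyl in place of methyl on an aromatic carbon.

Going by the values given here, only one measured step touches the same aromatic carbon, namely the exchange of methyl in place of chloro, a number 2 percentage points higher from compound 2 to compound 3 (within the scatter), which stayed within the scatter. Among the compounds with values here, no measured step brings a phenyl in at this or any other position, so the size of the present change is not covered by the data. Within the data shown here, the one step at this carbon gives no reason to expect a move beyond the scatter, but the entering group is far larger than anything tried there, so the range must be wide. The step of a number 5 percentage points higher from compound 3 to compound 4 (within the scatter) is therefore expected to be small. Compound 4 is estimated to give 12%, with a range from 3% to 38%.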

Compound 4, a percentage reported as activity, at one concentration (the size of the read-out at that concentration, not a potency): 38%
The estimate for compound 4 lay 26 percentage points below the measured number; low and high end bracket the measured number.
By their numbers in this assay, from the lowest: compounds 2 and 3 (each within the scatter of the next); then compounds 1 and 4 (each within the scatter of the next).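

In this assay, this aromatic carbon does not accept every group alike: phenyl in place of methyl gives a number 31 percentage points higher from compound 3 to compound 4 (beyond the scatter) and phenyl in place of chloro gives a number 33 percentage points higher from compound 2 to compound 4 (beyond the scatter) at the same concentration. Both steps point to a weaker effect with phenyl at this carbon. The earlier exchange of methyl in place of chloro gave only a number 2 percentage points higher from compound 2 to compound 3 (within the scatter) here, so the tolerance seen between those two groups does not extend to phenyl, with its six heavy atoms and its aromatic ring.

The compounds shown do not separate the ring itself from the number of heavy atoms, and an ethyl, a cyclopropyl or a pyridyl group at this carbon would bear on that question, while a single concentration leaves potency unsettled. There is no supporting evidence that bears on this result, so the weaker effect of compound 4 stays an observation without an assigned reason.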